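An Ether-Bearing Side Chain on a Shared Core

The source may report more compounds than this note shows. Statements on the series, on what has been measured and on what is new or still open speak of the compounds shown alone.

In a functional assay for antagonist activity at corticotropin-releasing factor receptor 1 (Rattus norvegicus) (on this read-out higher numbers stand for weaker inhibition and lower numbers for stronger inhibition), two compounds built on one shared core have been measured so far. Compound 1 `CC[C@H](C1CC1)n1c(=O)c(C)nc2c(-c3cc(F)c(OC)cc3C)ccnc21` gives 9.4 nM. Compound 2 `CCCC(C)n1c(=O)c(C)nc2c(-c3ccc(Cl)cc3Cl)ccnc21` gives 62 nM, the higher of the two numbers, and the gap between compound 1 and compound 2 lies beyond the usual scatter of repeated measurements. Since the two differ in more than one place, their values alone do not assign the gap to any single change.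

Compound 3 `CC[C@H](COC)n1c(=O)c(C)nc2c(-c3ccc(Cl)cc3Cl)ccnc21` has not yet been measured. It differs from compound 2 in one place only: 1-(methoxymethyl)propyl in place of 1-methylbutyl on an aromatic nitrogen. Among the compounds with values here, no measured pair in this set isolates such an exchange, so no step can be quoted for it, and any expectation rests on compound 2 alone, with its value of 62 nM. The expectation for compound 3 is a small step, if any, towards a lower number, nothing far beyond the scatter. Compound 3 is therefore estimated in this assay at 40 nM, with a range from 10 nM to 160 nM, which is expected to amount to a 1.6-fold lower number from compound 2 to compound 3 (0.19 log units; within the scatter).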

Compound 3, half-maximal inhibitory concentration: 4 nM
The estimate for compound 3 lay 10-fold (1.00 log units) above the measured number; the whole stated range lies above it.
By their numbers in this assay, from the lowest: compound 3; then compound 1; then compound 2.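

In this assay, this result shows that the side chain on an aromatic nitrogen is a place where one exchange alone can move the read-out well beyond the scatter: 1-(methoxymethyl)propyl in place of 1-methylbutyl gives a 16-fold lower number from compound 2 to compound 3 (1.19 log units; beyond the scatter), towards stronger inhibition. The earlier compounds shown here differed in more than one place and could not assign any gap to this position, whereas here the rest of the structure stays the same and the change is confined to the side chain, which gains one oxygen, one hydrogen-bond acceptor and a defined stereocentre. Nothing available explains why the step is this large.

What the compounds leave open is whether the oxygen or the defined stereocentre carries the step, since the two enter together and the opposite stereoisomer of compound 3 is not among those shown. They also leave open whether the same exchange would give a similar step on the aromatic group of compound 1, and how a hydroxyl, an amine or a longer ethoxymethyl chain would compare with the methoxymethyl arm at this position.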